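The compounds below may be only part of what the source reports. "The series", "measured", "known", "first", "only" and "open" are said of these compounds alone.

Values in a functional assay on HEK293 cells for negative allosteric modulation of metabotropic glutamate receptor 5 (Homo sapiens), read by calcium flux, with a stated time of 20 min (on this read-out higher numbers stand for weaker inhibition and lower numbers for stronger inhibition), for the three measured compounds:

compound 1 `O=C(c1ccccc1)N1CCn2nc(-c3ccc(F)cn3)cc2C1`: 164 nM
compound 2 `O=C(c1ccccc1)N1CCn2nc(-c3ccc(Cl)cn3)cc2C1`: 201 nM
compound 3 `O=C(c1cccc(Cl)c1)N1CCn2nc(-c3ccc(F)cn3)cc2C1`: 150 nM

All three numbers sit close together. The step of a 1.2-fold lower number from compound 2 to compound 1 (0.09 log units; within the scatter) comes from fluoro in place of chloro on an aromatic carbon. The step of a 1.1-fold lower number from compound 1 to compound 3 (0.04 log units; within the scatter) comes from chloro in place of hydrogen on an aromatic carbon of the benzoyl ring. The difference between the cores of compound 3 and compound 2 is not broken down here; their two values show only that they lie within the scatter of each other. In this assay, going by the values given here, compound 3 gives 150 nM, and no compound can be called the most potent, since every gap is within the scatter.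

Compound 4 `O=C(c1cccc(F)c1)N1CCn2nc(-c3ccc(F)cn3)cc2C1` is not yet measured. It differs from compound 3 by fluoro in place of chloro on an aromatic carbon. Among the compounds with values here, this is the same kind of change as the one from compound 2 to compound 1, though not at the same place: there the fluoro sat on a six-membered aromatic ring with one nitrogen, two atoms from the ring nitrogen and para to a large group, whereas here it sits on a six-membered aromatic ring of carbon only, meta to a large group. The earlier swap moved the number only within the scatter, so the step from compound 3 to compound 4 is expected to be small as well, a 1.1-fold higher number from compound 3 to compound 4 (0.03 log units; within the scatter), resting on a 1.2-fold lower number from compound 2 to compound 1 (0.09 log units; within the scatter) and on compound 3 giving 150 nM. Compound 4 is therefore estimated at 160 nM in this assay, with a range from 80 nM to 320 nM expected.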

Compound 4, half-maximal inhibitory concentration: 257 nM
Estimate against measurement, compound 4: 1.6-fold (0.21 log units) below; low and high end bracket the measured number.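

Fluoro in place of chloro has now been read on two cores in this assay, and the two readings cannot be told apart: the same change on two cores in this assay, a 1.2-fold lower number (0.09 log units; within the scatter) from compound 2 to compound 1 and a 1.7-fold higher number (0.23 log units; within the scatter) from compound 3 to compound 4, 2.1-fold (0.32 log units) apart, within the scatter of two such steps

On the core of compound 3, the change from 3-chlorophenyl to 3-fluorophenyl gives a 1.7-fold higher number from compound 3 to compound 4 (0.23 log units; within the scatter), and fluoro in place of hydrogen on the same ring gives a 1.6-fold higher number from compound 1 to compound 4 (0.20 log units; within the scatter), so neither halogen swap on this ring moves the number beyond the scatter. This does not show that the change carries over with a fixed size, nor that its size depends on the core: each core offers a single pair, and the two swaps sit at different places, one on a six-membered aromatic ring with one nitrogen and the other on a six-membered aromatic ring of carbon only, so core and place cannot be separated.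

Left open is whether a group other than a halogen on the aromatic carbon meta to a large group, such as methoxy, nitrile or trifluoromethyl, would give a step beyond the scatter. Also open, on these data alone, is whether an amine or a carboxylic acid at that place would leave the number as close to the others as fluoro and chloro do.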